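Pyridin-3-yl in place of 1-methyl-1H-pyrazol-3-yl in compound 3

The source may report more compounds than this note shows. Statements on the series, on what has been measured and on what is new or still open speak of the compounds shown alone.

Measured so far in a physicochemical assay for lipophilicity, using the shake flask method, in phosphate buffer, measured as octanol-water partition, with a stated time of 30 min, at pH 7.4; on this read-out higher numbers stand for higher lipophilicity and lower numbers for lower lipophilicity
Compound 1 `CN(c1ncco1)c1cnc(NCc2c(F)ccc3c2CCO3)n2cnnc12` gives 2.1
Compound 2 `CN(C)C(=O)c1cc(-c2cnc(NCc3c(F)ccc4c3CCO4)c3cn[nH]c(=O)c23)n(C)n1` gives 2.1
Compound 3 `CN(c1ccn(C)n1)c1cnc(NCc2c(F)ccc3c2CCO3)n2cnnc12` gives 1.8

These three values lie within the usual scatter of one another, so compound 3 at 1.8 is not set apart from the other two. Compound 4 `CN(c1cccnc1)c1cnc(NCc2c(F)ccc3c2CCO3)n2cnnc12` has pyridin-3-yl in place of 1-methyl-1H-pyrazol-3-yl on a nitrogen on an aromatic ring. For the measured compounds named here, one measured step bears on this place, namely a number 0.30 log units lower from compound 1 to compound 3 (within the scatter) for 1-methyl-1H-pyrazol-3-yl in place of 1,3-oxazol-2-yl. Going by the values given here, no measured step involves pyridin-3-yl itself, so no change beyond the scatter is expected in this assay here. The expected step is a number 0.20 log units higher from compound 3 to compound 4 (within the scatter) and it is estimated to stay within the scatter. For compound 4 the estimated value is 2 with an expected range from 1.6 to 2.4 on this scale.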

Compound 4, distribution coefficient: 2.6
Compound 4: the middle estimate sits 0.60 log units below what was measured; measured number outside the range, above it.
By their numbers in this assay, from the lowest: compounds 3, 1 and 2 (each within the scatter of the next); then compound 4.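

In this assay, this position on the nitrogen can move the number beyond the scatter: pyridin-3-yl in place of 1-methyl-1H-pyrazol-3-yl gives a number 0.80 log units higher from compound 3 to compound 4 (beyond the scatter), and pyridin-3-yl in place of 1,3-oxazol-2-yl gives a number 0.50 log units higher from compound 1 to compound 4 (beyond the scatter). For the compounds shown here, the earlier exchange between the other two groups stayed within the scatter, so compound 4 is the first compound here set apart from the others by a change at this place. No evidence is available on what lies behind this rise.

As far as these compounds go, whether a plain phenyl ring on the same nitrogen would stand with compound 4 or with compound 3 remains open. So does the effect of an amine or a methoxy group carried on the pyridin-3-yl ring.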